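This account rests on a few compounds, and the source may have more. Where it says the series, first, only, none or still open, it means among the compounds named here.

Measured in an assay on isolated protein for inhibition of acid ceramidase (Homo sapiens), read by LC-MS, with a stated time of 1 h; on this read-out higher numbers stand for weaker inhibition and lower numbers for stronger inhibition:
compound 1 `O=C(NCCCCc1ccccc1)n1cc(-c2ccccc2)oc1=O` gives 90 nM
compound 2 `O=C(NCCCCc1ccccc1)n1cc(-c2ccccn2)oc1=O` gives 25 nM
compound 3 `O=C(NCCCCc1ccccc1)n1cc(-c2ccncc2)oc1=O` gives 18 nM

Compound 1 stands at the highest number of the three. The step of a 3.6-fold lower number from compound 1 to compound 2 (0.56 log units; beyond the scatter) and the step of a 5.0-fold lower number from compound 1 to compound 3 (0.70 log units; beyond the scatter) both lower the number beyond the scatter, while the step of a 1.4-fold lower number from compound 2 to compound 3 (0.14 log units; within the scatter) lies within the scatter.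

Compound 4 `CN1CCC(c2cccc(-c3cn(C(=O)NCCCCc4ccccc4)c(=O)o3)c2)CC1` differs from compound 1 by 1-methylpiperidin-4-yl in place of hydrogen on an aromatic carbon. Among the compounds with values here, no measured step makes a change of this kind: each of them swaps the whole aromatic ring for a pyridyl, whereas here the ring stays and a group is added to it. Within the data shown here, the measured steps show only that changes at this ring have so far been tolerated in this assay, with modest gains. On that thin basis a step of modest size in either direction, or none beyond the scatter, is expected. For compound 4 the expected step in this assay is a 1.5-fold lower number from compound 1 to compound 4 (0.18 log units; within the scatter). The estimate for compound 4 is 60 nM, with a wide range from 15 nM to 250 nM.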

Compound 4, half-maximal inhibitory concentration: 153 nM
Compound 4: the middle estimate sits 2.6-fold (0.41 log units) below what was measured; low and high end bracket the measured number.
By their numbers in this assay, from the lowest: compounds 3 and 2 (each within the scatter of the next); then compounds 1 and 4 (each within the scatter of the next).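

In this assay, 1-methylpiperidin-4-yl added on an aromatic carbon of the six-membered aromatic ring of carbon only, meta to a large group, gives a 1.7-fold higher number from compound 1 to compound 4 (0.23 log units; within the scatter). The earlier steps shown here all swapped the whole ring for a pyridyl, whereas this one keeps the ring of compound 1 and shows that it accepts a six-membered non-aromatic ring with no step beyond the scatter. No measurement here bears on why the added group leaves the number within the scatter.

On these data alone, it remains open whether a smaller amine such as dimethylamino, or a carboxylic acid, at this same place would read the same way. Also open, as far as these compounds go, is whether 1-methylpiperidin-4-yl on the pyridin-4-yl ring of compound 3, which gives 18 nM, would leave that number within the scatter.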